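Methyl in place of carboxy on the piperidine ring

The compounds below may be only part of what the source reports. "The series", "measured", "known", "first", "only" and "open" are said of these compounds alone.

Measured compounds:
compound 1 `C(=C/c1ccccc1OCCCCN1CCNCC1)\c1ccccc1`: 0%
compound 2 `O=C(O)C1CCCN(CCCCOc2ccccc2/C=C/c2ccccc2)C1`: 12.5%

In a functional assay on the whole organism with Mus musculus as the target, in the maximal electroshock model, at a dose of 50 mg/kg by the oral route (on this read-out higher numbers stand for more inhibition at the one dose given (going by the name of the read-out) and lower numbers for less inhibition), compound 1 gives 0%, while compound 2 gives 12.5%. Compound 2 therefore stands highest of the two numbers; its nearest neighbour is compound 1, and the step of a number 12.5 percentage points higher from compound 1 to compound 2 (beyond the scatter) lies beyond the scatter, though it is a modest one.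

Compound 3 `CC1CCCN(CCCCOc2ccccc2/C=C/c2ccccc2)C1` has not been measured. It differs from compound 2 in one place: methyl in place of carboxy on a saturated ring carbon.

Within the data shown here, only one measured step exists, a number 12.5 percentage points higher from compound 1 to compound 2 (beyond the scatter), and it concerns a change of the whole ring on the chain carbon, not a change on a saturated ring carbon of the piperidine. Among the measured compounds shown here, no measured pair isolates the carboxy to methyl exchange, so the bearing of that step on compound 3 is indirect. Given that both measured compounds sit low in this assay and that their one step is modest, the expected step of no change at the digits printed from compound 2 to compound 3 (within the scatter) is small and may not exceed the scatter. Compound 3 is thus estimated at 12.5%, with a range from 0% to 37.5%.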

Compound 3, a percentage reported as inhibition, in the whole organism at one dose (the size of the read-out at that dose, not a potency): 12.5%
Beside the measured number, compound 3's estimate shows no gap at the digits printed; measured number inside the range.
By their numbers in this assay, from the lowest: compound 1; then compounds 2 and 3 (each within the scatter of the next).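

In this assay, methyl in place of carboxy on a saturated ring carbon, two ring bonds from the ring nitrogen, gives no change at the digits printed from compound 2 to compound 3 (within the scatter), so this read-out does not separate the two groups at this position, even though the hydrogen-bond donor and acceptor of the carboxy leave with it. The step of a number 12.5 percentage points higher from compound 1 to compound 3 (beyond the scatter) shows that the 3-methylpiperidin-1-yl compound also stands clear of the piperazin-1-yl compound, so among these compounds that difference does not require a carboxy on the ring. No measurement at hand offers an explanation for this result.

The compounds shown leave open whether a piperidin-1-yl ring with no added group, or one with an amine or a hydroxymethyl at the same ring carbon, would read alike in this assay. They also leave open whether a longer chain in place of the present one, carrying the same 3-methylpiperidin-1-yl or 3-carboxypiperidin-1-yl, would change the reading at all.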